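The source may report more compounds than this note shows. Statements on the series, on what has been measured and on what is new or still open speak of the compounds shown alone.

Working notes on the series. Among the compounds with values here, compound 2 `Cc1nn(-c2ncnc3nc[nH]c23)c2c1C(OCc1ccccc1F)CC(=O)N2` gives 78 nM in a functional assay on HEK293 cells for agonist activity at G-protein coupled receptor 39 (Homo sapiens), read by scintillation proximity assay and inositol phosphate accumulation, with a stated time of 75 min (a higher number here means that more compound is needed for the effect, a lower number that less compound is needed), and stands lowest of the two numbers measured so far. Within the data shown here, compound 1 `Cc1nn(-c2ncnc3nc[nH]c23)c2c1C(OCC(=O)c1ccc(F)cc1)CC(=O)N2` gives 973 nM in this assay, and the only measured step, a 12-fold lower number from compound 1 to compound 2 (1.10 log units; beyond the scatter), concerns the same saturated ring carbon that is now varied again. Compound 3 `Cc1nn(-c2ncnc3nc[nH]c23)c2c1C(C(=O)NCc1ccccc1)CC(=O)N2` is not yet measured; the change from compound 2 is benzylcarbamoyl in place of (2-fluorobenzyl)oxy on a saturated ring carbon. The step from compound 1 to compound 2 bears on the present change only in showing that this position responds strongly to changes in the chain carrying the phenyl ring; it gives no direction for replacing an ether by an amide. A step well beyond the scatter is therefore plausible in either direction, and a moderate rise in the number is taken as the central expectation. Compound 3 is expected to give 250 nM in this assay, within a range from 60 nM to 1000 nM. This expectation corresponds to an estimated step of a 3.2-fold higher number from compound 2 to compound 3 (0.51 log units; beyond the scatter).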

Compound 3, half-maximal effective concentration: 2930 nM
The estimate for compound 3 lay 12-fold (1.07 log units) below the measured number; measured number above the stated range.
By their numbers in this assay, from the lowest: compound 2; then compound 1; then compound 3.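

Replacing (2-fluorobenzyl)oxy by benzylcarbamoyl on the saturated ring carbon gives, in this assay, a 38-fold higher number from compound 2 to compound 3 (1.57 log units; beyond the scatter), so the position responds strongly not only to changes further along a chain attached through oxygen, as in compound 1 and compound 2, but also to the change of the attachment itself. Compound 3 also has a higher number than compound 1, so a phenyl ring on the chain does not alone keep the number low. No measurement here accounts for the size of this step.

The step combines the change of link with the loss of the fluorine, and the compounds shown do not separate the two. A (2-fluorobenzyl)carbamoyl group or an unsubstituted benzyloxy group at this carbon would divide the step between them.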